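Fluorophenyl position on the piperazine amide series

A few compounds are considered here, and "the series" means these few. Any claim that something is new, unique, unknown or untested is made for them only; others in the source may bear on it.

Among the compounds with values here, compound 2 `CC(C(=O)N1CCN(c2ccccc2F)CC1)N1C(=O)CCC1=O` is the weaker of the two compounds measured so far: in a functional assay on the whole organism (strain Swiss) with Mus musculus as the target, in the maximal electroshock model, with a stated time of 1 h, at a dose of 100 mg/kg by the intraperitoneal route (on this read-out higher numbers stand for a stronger effect at the one dose given and lower numbers for a weaker effect), compound 2 gives 0%. Compound 1 `CC(C(=O)N1CCN(c2cccc(Cl)c2)CC1)N1C(=O)CCC1=O` is the other measured compound, and in this assay compound 1 gives 50%. Within the data shown here, the one measured step between them is a number 50 percentage points lower from compound 1 to compound 2 (beyond the scatter); it changes both the halogen and its position on the ring at the same time, so it does not isolate either part.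

Compound 3 `CC(C(=O)N1CCN(c2cccc(F)c2)CC1)N1C(=O)CCC1=O` is not yet measured. Its difference from compound 2 is 3-fluorophenyl in place of 2-fluorophenyl on an amine nitrogen in a ring. This change returns the halogen to the position it occupies in compound 1, while keeping fluorine rather than chlorine. Among the measured compounds shown here, no measured step bears on that move alone. Because compound 1 with its halogen in that position reaches 50%, a rise from compound 2 is expected rather than a further fall, but the halogen itself differs, so the size is uncertain. The expected step is a number 30 percentage points higher from compound 2 to compound 3 (beyond the scatter). For compound 3 in this assay the estimate is 30%, with a range from 0% to 60%.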

Compound 3, a percentage reported as activity, at one dose (the size of the read-out at that dose, not a potency): 0%
Beside the measured number, compound 3's estimate is 30 percentage points above it; low and high end bracket the measured number.
By their numbers in this assay, from the lowest: compounds 2 and 3 (each within the scatter of the next); then compound 1.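

In this assay, the fluorine's place on the phenyl ring makes no difference that can be read, with no change at the digits printed from compound 2 to compound 3 (within the scatter); at this one dose, the 2-fluorophenyl and 3-fluorophenyl groups cannot be told apart. The comparison with compound 1 now isolates the halogen, which the earlier step could not do: fluoro in place of chloro on an aromatic carbon gives a number 50 percentage points lower from compound 1 to compound 3 (beyond the scatter), so among these compounds, the chloro compound alone shows activity in this test, and moving fluorine does not recover it. Nothing available explains why the exchange of halogen has so large an effect.

The compounds shown leave open whether a 2-chlorophenyl group would match the 3-chlorophenyl group of compound 1, and whether a bromo or trifluoromethyl group in place of its chloro would keep, lose or raise the effect. From the compounds shown here alone, since compound 2 gives 0% and compound 3 gives 0%, it also remains open whether the two fluorophenyl compounds would separate under other test conditions.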